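Side-chain swaps on the amide: microsomal clearance notes

The source may hold more compounds than are shown below. What is called first, only, known or untested is meant among the compounds shown, and "the series" means these compounds.

Values in an in vitro ADME assay on microsomes from liver (Homo sapiens) for metabolic stability, using NADPH (a lower number here means slower removal, a higher number faster removal of the compound), are as follows
- compound 1 `COc1ccc(OC(F)(F)F)cc1Cn1c(C(=O)NCC(C)(C)CO)cc2cc(C#N)ccc21` gives 69 mL.min-1.g-1
- compound 2 `COc1ccc(OC(F)(F)F)cc1Cn1c(C(=O)NCC2(CO)CC2)cc2cc(C#N)ccc21` gives 139 mL.min-1.g-1

Among the measured compounds shown here, the only measured step is a 2.0-fold higher number from compound 1 to compound 2 (0.30 log units; within the scatter) for 1-(hydroxymethyl)cyclopropyl in place of 1-(hydroxymethyl)-1-methylethyl on a saturated chain carbon bound to an amide-type nitrogen. Compound 2 thus stands level with compound 1 within the scatter, and neither can be ranked.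

Next comes compound 3 `COc1ccc(OC(F)(F)F)cc1Cn1c(C(=O)NCC(C)(C)O)cc2cc(C#N)ccc21` where the change from compound 2 reads 1-hydroxy-1-methylethyl in place of 1-(hydroxymethyl)cyclopropyl on a saturated chain carbon bound to an amide-type nitrogen and the three-membered ring is lost. Compound 1 also has no such ring and gives 69 mL.min-1.g-1 in this assay so it is the closest guide, although its side chain differs from that of compound 3. For the measured compounds named here, the single measured step (a 2.0-fold higher number from compound 1 to compound 2 (0.30 log units; within the scatter)) bears only in part on this change, and it sets the scale. A move toward a lower number is expected, of similar size and not clearly beyond the scatter. The expected step is a 1.9-fold lower number from compound 2 to compound 3 (0.27 log units; within the scatter) on this reasoning. For compound 3 the estimated value is 75 mL.min-1.g-1 with an expected range from 35 mL.min-1.g-1 to 150 mL.min-1.g-1 in this assay.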

Compound 3, intrinsic clearance in microsomes: < 6 mL.min-1.g-1
Compound 3: no number, only a limit (the forecaster's own chance of this, stated with the estimate: 3%); middle value at least 12-fold (1.09 log units) away from the limit.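

In this assay compound 3 gives a limit of the assay and not a number: the limit of < 6 mL.min-1.g-1 in this assay, at which 1 of the 3 values shown sits.

Two large steps lead to it, both beyond the scatter: an at least 23-fold lower number from compound 2 to compound 3 (1.36 log units; beyond the scatter) with 1-hydroxy-1-methylethyl in place of 1-(hydroxymethyl)cyclopropyl, and an at least 11-fold lower number from compound 1 to compound 3 (1.06 log units; beyond the scatter) with hydroxy in place of hydroxymethyl on a saturated chain carbon bound to three saturated chain carbons. The swap between compound 1 and compound 2 left the two within the scatter of each other, whereas these steps show that the side chain on the amide nitrogen can strongly change the read-out, and since compound 1 has no three-membered ring either, loss of that ring is not needed for the difference from compound 3.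

The limit leaves the full size of both steps unknown, and the compounds shown give no cause for them. From the compounds shown here alone, it remains open whether an amine or a carboxylic acid in place of the hydroxy of 1-hydroxy-1-methylethyl, or a longer chain carrying that hydroxy, would stay as low in this assay as compound 3.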